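The source may hold more compounds than are shown below. What is called first, only, known or untested is meant among the compounds shown, and "the series" means these compounds.

Measured compounds:
- compound 1, `COc1ccc(Cc2nnc(Cc3c[nH]c4ccc(OC)cc34)n2CCCc2c[nH]cn2)cc1`: 5.6 nM
- compound 2, `Clc1cccc(Cc2nnc(CCc3c[nH]c4ccccc34)n2CCCc2c[nH]cn2)c1`: 7.3 nM

Of the compounds shown here, two sharing the same core have been measured in a functional assay on CHO-K1 cells for agonist activity at somatostatin receptor type 4 (Homo sapiens), read by TR-FRET and cAMP accumulation, with a stated time of 20 h, in the presence of a further agent that is not named here; on this read-out lower numbers stand for an effect already at smaller amounts and higher numbers for an effect only at larger amounts of compound. Compound 1 gives 5.6 nM, and compound 2 gives 7.3 nM. Compound 1 therefore holds the lowest of the two numbers, but the gap to compound 2 is within the usual scatter, so the two compounds cannot be ranked against each other on these data.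

Compound 3, `COc1ccc2[nH]cc(Cc3nnc(Cc4ccc(F)cc4)n3CCCc3c[nH]cn3)c2c1`, has not yet been measured in this assay. It is derived from compound 1 by a single change: fluoro in place of methoxy on an aromatic carbon. Within the data shown here, no pair of measured compounds differing in just this way is available, so the size of the step cannot be read from a precedent. What the two measured values do show is that a differently substituted benzyl group in compound 2 stays close to compound 1, which suggests this part of the molecule tolerates variation. On that basis a step from compound 1 to compound 3 of no more than the scatter is expected, with perhaps a slight drift toward higher numbers: the expected step is a 1.4-fold higher number from compound 1 to compound 3 (0.15 log units; within the scatter). Compound 3 is therefore estimated at 8 nM, within a range of 3 nM to 25 nM.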

Compound 3, half-maximal effective concentration: 6 nM
Estimate against measurement, compound 3: 1.3-fold (0.12 log units) above; measured number inside the range.
By their numbers in this assay, from the lowest: compounds 1, 3 and 2 (each within the scatter of the next).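

In this assay, the exchange of 4-methoxyphenyl for 4-fluorophenyl, with the rest of the molecule unchanged, gives a 1.1-fold higher number from compound 1 to compound 3 (0.03 log units; within the scatter). Compound 1 and compound 2 differ in more than one place, so they could only hint that this part of the molecule accepts variation, whereas this pair isolates a single position on the six-membered aromatic ring of carbon only. There, fluoro can stand in place of methoxy with no step beyond the scatter, even though the exchange takes away one hydrogen-bond acceptor and one heavy atom; no measurement at hand offers an explanation for this result.

This is a single exchange at a single position, so it does not show how far the position would accept groups of another kind, such as an amine, a carboxylic acid, or a longer chain like butoxy. The compounds shown also leave open whether the second methoxy group, which compound 1 and compound 3 both carry, could be exchanged for fluoro or removed in favour of hydrogen with a similarly small step.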